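Compound 4: a sulfur-to-nitrogen swap at a limit

A few compounds are considered here, and "the series" means these few. Any claim that something is new, unique, unknown or untested is made for them only; others in the source may bear on it.

Measured in an ADME assay on HFF cells (Homo sapiens) for cytotoxicity, with a stated time of 8 days (on this read-out lower numbers stand for higher toxicity in this test and higher numbers for lower toxicity in this test), each value a limit and not a number:
Compound 1 `C=CCOc1nc(N)nc2c1ncn2/C=C1/CC1(CO)CO`: > 300000 nM
Compound 2 `COCCOc1nc(N)nc2c1ncn2/C=C1/CC1(CO)CO`: > 300000 nM
Compound 3 `CCCSc1nc(N)nc2c1ncn2/C=C1/CC1(CO)CO`: > 300000 nM

Compound 3 stands only at a limit, > 300000 nM. Across the series the picture is the limit of > 300000 nM in this assay, at which 3 of the 3 values shown sit. Compound 4 `CCCNc1nc(N)nc2c1ncn2/C=C1/CC1(CO)CO` differs from compound 3 by one change: propylamino in place of propylsulfanyl on an aromatic carbon. Two measured changes at that carbon bear on it, a step that the two limits leave unreadable from compound 1 to compound 3 and a step that the two limits leave unreadable from compound 2 to compound 3, and the side-chain change a step that the two limits leave unreadable from compound 1 to compound 2 bears on it less directly. None has a readable size, so no step beyond the scatter, in either direction, is expected in this assay. The expected step is a number no higher from compound 3 to compound 4 (the limit leaves the size open). For compound 4 the estimate is 300000 nM, with an expected range of 150000 nM to 600000 nM.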

Compound 4, half-maximal cytotoxic concentration: > 300000 nM
Compound 4 was reported as a limit; the forecaster's own chance of this, stated with the estimate: 75%; the middle value lies on the limit itself.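

In this assay compound 4 also stands only at a limit, so no step can be read between it and compound 1, compound 2 or compound 3. As far as these compounds go, whether these four compounds differ at all in this read-out stays open.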